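The source may report more compounds than this note shows. Statements on the series, on what has been measured and on what is new or still open speak of the compounds shown alone.

Measured so far:
compound 1, `CCC(=O)Nc1cccc(Oc2nc(Nc3ccc(N4CCN(C)CC4)cc3)ncc2Cl)c1`: 82.6%
compound 2, `CCC(=O)Nc1cccc(Oc2nc(Nc3ccc(N4CCC(OC)CC4)cc3)ncc2Cl)c1`: 53.4%

In an assay on isolated protein for inhibition of NUAK family SNF1-like kinase 2 (Homo sapiens), read by ADP-Glo, with a stated time of 60 min, tested at 10 uM, in the presence of a further agent that is not named here (on this read-out lower numbers stand for less inhibition and higher numbers for more inhibition at the one concentration tested (going by the name of the read-out)), compound 2 stands lowest of the two numbers; its nearest neighbour is compound 1, and the only shown step, a number 29.2 percentage points lower from compound 1 to compound 2 (beyond the scatter), runs downward beyond the scatter. The next compound is compound 3, `CCC(=O)Nc1cccc(Oc2nc(Nc3ccc(N4CCCCC4)cc3)ncc2Cl)c1`. Compared with compound 2 it carries hydrogen in place of methoxy on a saturated ring carbon, that is, 4-methoxypiperidin-1-yl becomes piperidin-1-yl. For the measured compounds named here, no measured step touches this methoxy; the one step known concerns the exchange of 4-methylpiperazin-1-yl for 4-methoxypiperidin-1-yl, which is a different change and gives no direct guide. With the ring nitrogen and the rest of compound 2 kept, no step beyond the scatter is expected in this assay for compound 3, though the direction is uncertain. Compound 3 is therefore expected at about 50%, within 30% to 70%, a step of a number 3.4 percentage points lower from compound 2 to compound 3 (within the scatter) relative to compound 2.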

Compound 3, a percentage reported as inhibition, at one concentration (the size of the read-out at that concentration, not a potency): 72.3%
The estimate for compound 3 lay 22.3 percentage points below the measured number; measured number above the stated range.
By their numbers in this assay, from the lowest: compound 2; then compound 3; then compound 1.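

In this assay, the methoxy on this saturated ring carbon, three ring bonds from the ring nitrogen, is not a neutral passenger: hydrogen in its place gives a number 18.9 percentage points higher from compound 2 to compound 3 (beyond the scatter) and so recovers part of the number lost in a number 29.2 percentage points lower from compound 1 to compound 2 (beyond the scatter) on the way to 4-methoxypiperidin-1-yl. The recovery is incomplete, since piperidin-1-yl in place of 4-methylpiperazin-1-yl still gives a number 10.3 percentage points lower from compound 1 to compound 3 (beyond the scatter) in the same read-out, so the earlier drop now separates into one part tied to the methoxy and one tied to the ring exchange. Nothing at hand explains either step.

Open, from the compounds shown here alone, is whether a hydroxyl or a methyl on this ring carbon lowers the number as methoxy does. Also open, going by these compounds, is whether an unsubstituted piperazine, or a longer chain on its nitrogen, holds the level of compound 1 82.6%.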